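The source may report more compounds than this note shows. Statements on the series, on what has been measured and on what is new or still open speak of the compounds shown alone.

Measured compounds:
Compound 1 `Cc1ccc(/C=C2\Cc3ccccc3C2=O)cc1`: in a functional assay on L1210 cells (Mus musculus) for inhibition (on this read-out higher numbers stand for weaker inhibition and lower numbers for stronger inhibition), compound 1 gives 59100 nM.
Compound 2 `O=C1/C(=C/c2ccccc2)CCc2ccccc21`: in this assay compound 2 gives 121000 nM.
Compound 3 `O=C1/C(=C/c2cccc(F)c2)CCc2ccccc21`: in this assay compound 3 gives 61200 nM.

Compound 2 stands at the highest of the three numbers. Its nearest neighbour is compound 3, reached by the step of a 2.0-fold lower number from compound 2 to compound 3 (0.30 log units; within the scatter), which stays within the scatter. Compound 1 is furthest from compound 2; the gap between them is reported as beyond the scatter, with compound 1 at the lower number.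

Compound 4 `O=C1/C(=C/c2ccc(F)cc2)CCc2ccccc21` is not yet measured. It differs from compound 2 as follows: fluoro in place of hydrogen on an aromatic carbon.

Going by the values given here, the only measured step that bears on this change is the one from compound 2 to compound 3, where the same kind of change is made to the same ring, though at a different place: a 2.0-fold lower number from compound 2 to compound 3 (0.30 log units; within the scatter). That step stayed within the scatter. On this basis a small step toward a lower number, or none beyond the scatter, is expected for compound 4, a 1.7-fold lower number from compound 2 to compound 4 (0.24 log units; within the scatter). In this assay compound 4 is estimated at 70000 nM, with a range from 35000 nM to 140000 nM.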

Compound 4, half-maximal inhibitory concentration: 49300 nM
Beside the measured number, compound 4's estimate is 1.4-fold (0.15 log units) above it, and the stated range covers the measured number.
By their numbers in this assay, from the lowest: compounds 4, 1, 3 and 2 (each within the scatter of the next, the first and the last beyond it).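

In this assay, going by these compounds alone, fluoro para to a large group gives a 2.5-fold lower number from compound 2 to compound 4 (0.39 log units; beyond the scatter), a modest change and the first fluoro step to pass beyond the scatter, whereas a 2.0-fold lower number from compound 2 to compound 3 (0.30 log units; within the scatter) stays within it. This does not set one fluoro place above the other, since compound 3 at 61200 nM and compound 4 at 49300 nM lie within the scatter of each other. No supporting data bear on why this change lowers the number.

Whether the step depends on fluoro itself remains open, as no chloro, methoxy, amine or carboxylic acid at this place is among the compounds shown. Also open, as far as these compounds go, is what fluoro does on the other aromatic ring of the shared core.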